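From compound 2 to compound 4: an aryl exchange

The compounds below may be only part of what the source reports. "The series", "measured", "known", "first", "only" and "open" are said of these compounds alone.

In a functional assay on A549 cells (Homo sapiens) for inhibition, read by sulforhodamine B assay, with a stated time of 48 h, tested at 50 uM (on this read-out higher numbers stand for more inhibition of growth at the one concentration tested and lower numbers for less inhibition of growth), compound 2 `COc1ccc([C@@H]2C/C(=N/OCc3cn(-c4ccc(Cl)cc4C)nn3)c3cc(CC=C(C)C)c(OC)cc3O2)cc1` gives 35% and so sits within the scatter of compound 1 `COc1cc2c(cc1CC=C(C)C)C(=O)C[C@@H](c1ccc(Oc3ccc(F)cc3)cc1)O2` at 27% in this same read-out. Compound 3 `COc1cc2c(cc1CC=C(C)C)[C@H](O)C[C@@H](c1ccc(O)cc1)O2` gives 48% and lies beyond the scatter above both, holding the highest number of the three.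

Compound 4 `COc1ccc([C@@H]2C/C(=N/OCc3cn(-c4ccc(NC(C)=O)cc4)nn3)c3cc(CC=C(C)C)c(OC)cc3O2)cc1` departs from compound 2 in one place only, on an aromatic nitrogen of a five-membered aromatic ring with 3 nitrogen. The change there is 4-acetamidophenyl in place of 4-chloro-2-methylphenyl on an aromatic nitrogen and both groups have a six-membered aromatic ring of carbon only, with no net charge.

Within the data shown here, no two measured compounds differ in one place, so nothing measured sizes this exchange directly. Among the measured compounds shown here, compound 2 at 35% is the closest measured reference, and the three numbers so far span a modest range. No step beyond the scatter is expected in this assay, in either direction. The estimated step of a number 5 percentage points lower from compound 2 to compound 4 (within the scatter) stays inside the scatter. For compound 4 the estimated value is 30% (expected range 15% to 45%).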

Compound 4, percent growth inhibition at one concentration: 19%
Beside the measured number, compound 4's estimate is 11 percentage points above it; the range from low to high includes it.
By their numbers in this assay, from the lowest: compounds 4, 1 and 2 (each within the scatter of the next, the first and the last beyond it); then compound 3.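

In this assay, among these compounds, the first comparison that differs in one place shows that the group on the aromatic nitrogen of the five-membered ring matters: 4-acetamidophenyl in place of 4-chloro-2-methylphenyl gives a number 16 percentage points lower from compound 2 to compound 4 (beyond the scatter) as a step. This exchange changes several things together, removing the chlorine and the methyl and bringing in a hydrogen-bond donor and a hydrogen-bond acceptor that the leaving group lacks, and a single step cannot separate these contributions. No measurement is available to explain the step.

Still open, going by these compounds, is whether the step follows from the acetamido group entering or from the chlorine and methyl leaving; a plain phenyl, a 4-aminophenyl or a 4-chlorophenyl on the same nitrogen would begin to separate these. Also open, on these data alone, is how a 4-carboxyphenyl there would read in this assay, and whether this exchange gives a similar step on a core carrying a different group at the oxime end.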